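Extending the dimethylamino chain from compound 2 to compound 3

This account rests on a few compounds, and the source may have more. Where it says the series, first, only, none or still open, it means among the compounds named here.

Among the measured compounds shown here, in a functional assay on HL60/MX2 cells (Homo sapiens) for antiproliferative activity, read by MTT assay, with a stated time of 48 h (a higher number here means a weaker inhibitor, a lower number a stronger inhibitor), compound 2 (`CN(C)CCCn1c(N)c(-c2nc3ccccc3s2)c2nc(C#N)c(C#N)nc21`) gives 1310 nM and is so far the only compound with a true number. Compound 1 (`CN(C)CCn1c(N)c(-c2nc3ccccc3s2)c2nc(C#N)c(C#N)nc21`) gives > 50000 nM and this value is a limit of the assay. For the measured compounds named here, the single measured step bears directly on the next change: it is large and beyond the scatter, with an at least 38-fold lower number from compound 1 to compound 2 (1.58 log units; beyond the scatter) as its reading. Compound 3 (`CN(C)CCCCn1c(N)c(-c2nc3ccccc3s2)c2nc(C#N)c(C#N)nc21`) extends the chain once more, 3-(dimethylamino)propyl giving way to 4-(dimethylamino)butyl ((dimethylamino)methyl in place of dimethylamino on a saturated chain carbon, three bonds along the chain from an aromatic nitrogen). This is the same kind of change, but three bonds along the chain from an aromatic nitrogen rather than two. With one precedent and no trend established, only a small further drop in this assay is expected, possibly within the scatter. The expected step is a 1.5-fold lower number from compound 2 to compound 3 (0.16 log units; within the scatter) and it carries wide uncertainty. Compound 3 is estimated at 900 nM (expected range 220 nM to 5000 nM).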

Compound 3, half-maximal inhibitory concentration: 2140 nM
Compound 3: the middle estimate sits 2.4-fold (0.38 log units) below what was measured, within the range that was stated.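

In this assay, the change at this position, three bonds along the chain from an aromatic nitrogen, reads a 1.6-fold higher number from compound 2 to compound 3 (0.21 log units; within the scatter), so the large earlier step is not repeated and 3-(dimethylamino)propyl and 4-(dimethylamino)butyl cannot be told apart here. Set against 2-(dimethylamino)ethyl, the 4-(dimethylamino)butyl chain reads an at least 23-fold lower number from compound 1 to compound 3 (1.36 log units; beyond the scatter), so a large step is seen with both of the longer chains. Compound 1 is a limit and not a number, so the full size of each step from it stays unknown: the limit of > 50000 nM in this assay, at which 1 of the 3 values shown sits.

On these data alone, it remains open whether a longer chain, such as 5-(dimethylamino)pentyl, would stay within the scatter of these values. Also open, as far as these compounds go, is how the series would read with a primary amine, pyrrolidine or morpholine in place of dimethylamino at the chain end.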